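Swapping a Difluorophenyl for a Methylphenyl on the Alkyne

The source may report more compounds than this note shows. Statements on the series, on what has been measured and on what is new or still open speak of the compounds shown alone.

Compound 3 `C[C@@H](NC(=O)c1ccc(C#Cc2ccc(F)cc2F)cn1)C(C)(C)O` reaches 61.2% in a functional assay on HEK293 cells for positive allosteric modulation of metabotropic glutamate receptor 5 (Rattus norvegicus), read by fluorescence and calcium flux; on this read-out higher numbers stand for larger maximal responses and lower numbers for smaller maximal responses. Its two companions are close: compound 1 `C[C@@H](NC(=O)c1ccc(C#Cc2ccccc2)cn1)C(C)(C)O` gives 60.9% in this assay, and compound 2 `C[C@@H](NC(=O)c1ccc(C#Cc2ccc(F)cc2)cn1)C(C)(C)O` gives 66.2%. The three numbers sit together; the step of a number 0.3 percentage points higher from compound 1 to compound 3 (within the scatter) and the step of a number 5 percentage points lower from compound 2 to compound 3 (within the scatter) are both within the scatter, so compound 3 stands level with both neighbours rather than apart from them.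

Compound 4 `Cc1cccc(C#Cc2ccc(C(=O)N[C@H](C)C(C)(C)O)nc2)c1` carries the change (3-methylphenyl in place of 2,4-difluorophenyl on a triple-bonded carbon). Among the measured compounds shown here, the steps that bear on it all concern the ring on the triple-bonded carbon: a number 5.3 percentage points higher from compound 1 to compound 2 (within the scatter), a number 0.3 percentage points higher from compound 1 to compound 3 (within the scatter) and a number 5 percentage points lower from compound 2 to compound 3 (within the scatter). Each fell within the scatter, so exchanging one substituted phenyl for another at this position has so far left the maximal response unchanged. For the measured compounds named here, no measured step shows a methyl group at this place, so the picture is incomplete, but on the evidence at hand no step beyond the scatter is expected in either direction.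

Compound 4 is therefore expected to give about 62%, with a range from 50% to 74%; the expected step is a number 0.8 percentage points higher from compound 3 to compound 4 (within the scatter).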

Compound 4, largest response reached (reported as efficacy), in percent of the reference or control that the assay uses: 68.6%
Compound 4: middle estimate off by 6.6 percentage points, on the low side, and the stated range covers the measured number.
By their numbers in this assay, from the lowest: compounds 1, 3, 2 and 4 (each within the scatter of the next).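

Among the compounds shown here, a methyl group on the ring at this place, a substituent no earlier compound carried, also stays level in this assay and does not stand apart from the fluorinated or unsubstituted rings. The steps of a number 7.4 percentage points higher from compound 3 to compound 4 (within the scatter) and a number 2.4 percentage points higher from compound 2 to compound 4 (within the scatter) and a number 7.7 percentage points higher from compound 1 to compound 4 (within the scatter) all lie within the scatter. The triple-bonded carbon thus accepts 3-methylphenyl as it does phenyl, 4-fluorophenyl and 2,4-difluorophenyl, and no explanation for this level picture is available from any supporting measurement.

Going by these compounds, it remains open whether an amine, a carboxylic acid or a nitrile on this ring, or a pyridine in place of the phenyl, would give a step beyond the scatter. The compounds shown also leave open how the maximal response would follow a change to the amide side chain of the shared core.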